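The source may hold more compounds than are shown below. What is called first, only, known or untested is meant among the compounds shown, and "the series" means these compounds.

Compound 2 `Cc1ccc(-c2nnc(-c3ccc(CN4CCN(CCN)CC4)c(C(F)(F)F)c3)o2)cc1Nc1nccc(-c2cccnc2)n1` carries the only number shown in a functional assay on HL-60 cells (Homo sapiens) for inhibition, read by MTT assay, with a stated time of 72 h (on this read-out higher numbers stand for weaker inhibition and lower numbers for stronger inhibition), where compound 2 gives 20 nM. Compound 1 `Cc1ccc(-c2nnc(-c3ccc(F)c(C(F)(F)F)c3)o2)cc1Nc1nccc(-c2cccnc2)n1` reaches only the limit of this assay, > 30000 nM. Going by the values given here, the single measured step, an at least 1500-fold lower number from compound 1 to compound 2 (3.17 log units; beyond the scatter), is therefore open-ended at its start, since it rests on (the limit of > 30000 nM in this assay, at which 1 of the 2 values shown sits). Compound 3 `C=CC(=O)NCCN1CCN(Cc2ccc(-c3nnc(-c4ccc(C)c(Nc5nccc(-c6cccnc6)n5)c4)o3)cc2C(F)(F)F)CC1` differs from compound 2 by vinylcarbonyl in place of hydrogen on an amine nitrogen; the 2-aminoethyl on the piperazine becomes 2-((vinylcarbonyl)amino)ethyl. Among the compounds with values here, no measured step touches this amine nitrogen, so the one step recorded, which concerns the aromatic fluoro position, does not bear directly on it. Compound 3 is expected to stay close to compound 2, with the change amounting to no change at the digits printed from compound 2 to compound 3 (within the scatter) in this assay, a step not expected to exceed the scatter in either direction. Compound 3 is thus estimated at 20 nM, within a range from 5 nM to 80 nM.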

Compound 3, half-maximal inhibitory concentration: 2660 nM
For compound 3 the middle estimate is 130-fold (2.12 log units) below the measured one, outside the stated range (above it).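

In this assay, going by these compounds alone, vinylcarbonyl in place of hydrogen on the amine nitrogen gives a 130-fold higher number from compound 2 to compound 3 (2.12 log units; beyond the scatter), so this position, which no earlier step touched, is not indifferent to the change. The piperazine and its chain are present in both compounds, so their presence alone does not fix the number, and what stands on the end nitrogen of the chain counts as well. Nothing shown gives a reason for this step.

Going by these compounds, it stays open whether an acetyl group on the same nitrogen, which has no vinyl part, would read like compound 2 or like compound 3. Equally open, on these data alone, is how a methyl group on this nitrogen, a longer chain, or a carboxylic acid in place of the amine would read in this assay.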